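The compounds below may be only part of what the source reports. "The series", "measured", "known", "first", "only" and "open" are said of these compounds alone.

Measured compounds and their values:

Compound 1, `O=C(c1ccc(Cl)cc1)c1ccc2c(c1)oc(=O)n2C(=O)NCCCCc1ccccc1`, in an assay on HEK293 cells for inhibition of acid ceramidase (Homo sapiens), with a stated time of 10 min (a higher number here means a weaker inhibitor, a lower number a stronger inhibitor), gives 14 nM.
Compound 2, `Cc1ccc2c(c1)oc(=O)n2C(=O)NCCCCc1ccccc1`, gives 66 nM in this assay.
Compound 3, `O=C(NCCCCc1ccccc1)n1c(=O)oc2cc(-c3ccccc3)ccc21`, gives 84 nM in this assay.

Compound 3 has the highest number of the three, though its gap to compound 2 is within the scatter; only compound 1 stands clearly apart, with a 6.0-fold higher number from compound 1 to compound 3 (0.78 log units; beyond the scatter). Compound 4, `O=C(NCCCCc1ccccc1)n1c(=O)oc2cc(F)ccc21`, has not yet been measured in this assay. It differs from compound 3 at one place on the shared core: fluoro in place of phenyl on an aromatic carbon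

Among the compounds with values here, two measured steps bear on this change. The exchange of methyl for the (4-chlorophenyl)carbonyl group gave a 4.7-fold higher number from compound 1 to compound 2 (0.67 log units; beyond the scatter), and phenyl for that same group gave a 6.0-fold higher number from compound 1 to compound 3 (0.78 log units; beyond the scatter). Phenyl for methyl, however, gave only a 1.3-fold higher number from compound 2 to compound 3 (0.10 log units; within the scatter), so a small group and a six-membered ring at this position yield values within the scatter of each other. Fluoro is another small group at the same aromatic carbon, so no step beyond the scatter is expected in this assay; compound 4 is estimated at a 1.1-fold lower number from compound 3 to compound 4 (0.02 log units; within the scatter). The estimate for compound 4 is 80 nM, with a range from 35 nM to 180 nM.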

Compound 4, half-maximal inhibitory concentration: 31 nM
The estimate for compound 4 lay 2.6-fold (0.41 log units) above the measured number, outside the stated range (below it).
By their numbers in this assay, from the lowest: compound 1; then compound 4; then compounds 2 and 3 (each within the scatter of the next).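

In this assay, replacing phenyl with fluoro gave a 2.7-fold lower number from compound 3 to compound 4 (0.43 log units; beyond the scatter) and replacing methyl with fluoro gave a 2.1-fold lower number from compound 2 to compound 4 (0.33 log units; beyond the scatter) at this aromatic carbon. Methyl and phenyl had stayed within the scatter of each other, so this position was now seen to separate one small group from another, and methyl and fluoro were not interchangeable here. Fluoro still did not match the (4-chlorophenyl)carbonyl group, as replacing that group gave a 2.2-fold higher number from compound 1 to compound 4 (0.35 log units; beyond the scatter) and so left compound 1 with the lowest number of the four, while no measurement given here accounts for the difference between fluoro and the other groups.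

The compounds shown leave open how chloro, hydroxyl or an amine would stand against fluoro at this aromatic carbon, and whether a plain acetyl group would come close to the (4-chlorophenyl)carbonyl group. They also leave open whether the same order of these groups would hold with a longer chain in place of the one shared by all four compounds.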